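The source may report more compounds than this note shows. Statements on the series, on what has been measured and on what is new or still open speak of the compounds shown alone.

In an assay on Sf9 cells for inhibition of inhibitor of nuclear factor kappa-B kinase subunit epsilon (Homo sapiens), read by ADP-Glo, with a stated time of 60 min (on this read-out higher numbers stand for weaker inhibition and lower numbers for stronger inhibition), compound 1 `Cc1[nH]nc(N)c1-c1ccc(Cl)c(Cl)c1` gives > 100000 nM, which is a limit of the assay rather than a measured number. Compound 2 `Cc1[nH]nc(N)c1-c1cccc(C(F)(F)F)c1` likewise gives > 100000 nM, again only a limit. Compound 3 `CCC(=O)n1nc(C)c(-c2ccc(Cl)c(Cl)c2)c1N` gives > 100000 nM, also a limit. Compound 3 therefore has no distinct place among the numbers shown: all three values sit at the limit of > 100000 nM in this assay, at which 3 of the 3 values shown sit, and none can be told apart from the others. Compound 4 `Cc1nn(C(=O)c2ccncc2)c(N)c1-c1ccc(Cl)c(Cl)c1` has not been measured; it differs from compound 3 by pyridin-4-yl in place of ethyl on a carbonyl carbon. Going by the values given here, no measured pair shows what such a change does here, so the step that the estimate means, an at least 1.4-fold lower number from compound 3 to compound 4 (0.15 log units; that floor lies within the scatter), is expected to be small and of uncertain direction in this assay. Compound 4 is accordingly expected to give about 70000 nM, within 10000 nM to 300000 nM, quite possibly reported again only as a limit.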

Compound 4, half-maximal inhibitory concentration: > 100000 nM
Compound 4 ended at the assay's limit (the forecaster's own chance of this, stated with the estimate: 70%); middle value at least 1.4-fold (0.15 log units) from the limit.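

Going by these compounds alone, no step from compound 3 to compound 4 can be read, since neither gives a number, only the same limit: the limit of > 100000 nM in this assay, at which 4 of the 4 values shown sit. The compounds shown leave open whether pyridin-4-yl in place of ethyl changes inhibition at all, and which compound of this kind would give a readable value.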